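From a pyridine ring to a cyclopentane on the propenyl chain

The source may hold more compounds than are shown below. What is called first, only, known or untested is meant among the compounds shown, and "the series" means these compounds.

Compound 2 `O[C@@H](c1ccccc1)[C@H]1CO[C@H](c2ccccc2)[C@@H](C/C=C/c2ccccn2)C1` shares its core with compound 1 `CCCCCC/C=C/C[C@H]1C[C@@H]([C@@H](O)c2ccccc2)CO[C@@H]1c1ccccc1` and compound 3 `COc1ccc(/C=C/C[C@@H]2C[C@H]([C@H](O)c3ccc(OC)c(OC)c3)CO[C@H]2c2ccc(OC)c(OC)c2)cc1OC`. In a functional assay on HL-60 cells (Homo sapiens) for cytotoxicity, read by WST assay, with a stated time of 48 h (a lower number here means a stronger inhibitor, a higher number a weaker inhibitor), compound 1 gives 4990 nM, and compound 2 gives 36400 nM; for compound 3 the entry in this assay reads "not determined" (no result reported), so no result was reported. Going by the values given here, compound 2 therefore stands at the highest of the two numbers, with compound 1 as its only measured neighbour, and the single measured step, a 7.3-fold higher number from compound 1 to compound 2 (0.86 log units; beyond the scatter), followed from putting pyridin-2-yl in place of hexyl on a double-bonded chain carbon bound to a double-bonded chain carbon.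

Compound 4 `O[C@@H](c1ccccc1)[C@H]1CO[C@H](c2ccccc2)[C@@H](C/C=C/C2CCCC2)C1` is not yet measured. It differs from compound 2 as follows: cyclopentyl in place of pyridin-2-yl on a double-bonded chain carbon bound to a double-bonded chain carbon. Among the compounds with values here, only the step from compound 1 to compound 2 bears on this change, and it was modest but beyond the scatter. Since cyclopentyl is a ring of carbon only, without the nitrogen of pyridin-2-yl, a step back toward a lower number is expected in this assay, estimated as a 4.0-fold lower number from compound 2 to compound 4 (0.61 log units; beyond the scatter). Compound 4 is thus expected to give 9000 nM in this assay, within a range from 3000 nM to 27000 nM.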

Compound 4, half-maximal inhibitory concentration: 9060 nM
Estimate against measurement, compound 4: 1.0-fold (0.00 log units) below; the range from low to high includes it.
By their numbers in this assay, from the lowest: compounds 1 and 4 (each within the scatter of the next); then compound 2.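

In this assay cyclopentyl in place of pyridin-2-yl on this double-bonded chain carbon gives a 4.0-fold lower number from compound 2 to compound 4 (0.60 log units; beyond the scatter), so a ring at this place does not by itself carry the higher number of compound 2. Cyclopentyl in place of hexyl gives a 1.8-fold higher number from compound 1 to compound 4 (0.26 log units; within the scatter), which leaves the two carbon-only groups indistinguishable here, while pyridin-2-yl stands apart from both. Nothing measured here explains why pyridin-2-yl stands apart.

The compounds shown change the aromatic ring and the ring nitrogen together, so they cannot say which of the two goes with the higher number; phenyl at the same place would separate them. As far as these compounds go, how a cyclohexyl group or a longer chain, or a terminal amine, would read at this place also remains open.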